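Acyl variation on the proline nitrogen: three measured, one pending

This account rests on a few compounds, and the source may have more. Where it says the series, first, only, none or still open, it means among the compounds named here.

Compound 1 `CC(C)(C)OC(=O)N1CCC[C@H]1C(=O)N1CCC(NS(=O)(=O)c2cc(S(=O)(=O)c3ccccc3)ccc2C(F)(F)F)CC1`: 60 nM in a functional assay on U2OS cells for antagonist activity at proto-oncogene Wnt-3 (Homo sapiens), read by a luciferase reporter, with a stated time of 18 h; on this read-out higher numbers stand for an effect only at larger amounts of compound and lower numbers for an effect already at smaller amounts
Compound 2 `CC(C)C(=O)N1CCC[C@H]1C(=O)N1CCC(NS(=O)(=O)c2cc(S(=O)(=O)c3ccccc3)ccc2C(F)(F)F)CC1`: compound 2 gives 90 nM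
Compound 3 `CC(C)(C)CC(=O)N1CCC[C@H]1C(=O)N1CCC(NS(=O)(=O)c2cc(S(=O)(=O)c3ccccc3)ccc2C(F)(F)F)CC1`: compound 3 gives 120 nM

Compound 3 holds the highest of the three numbers, yet a 1.3-fold higher number from compound 2 to compound 3 (0.12 log units; within the scatter) and a 2.0-fold higher number from compound 1 to compound 3 (0.30 log units; within the scatter) both stay within the scatter, as does a 1.5-fold higher number from compound 1 to compound 2 (0.18 log units; within the scatter). Compound 4 `CN(C)c1ccc(C(=O)N2CCC[C@H]2C(=O)N2CCC(NS(=O)(=O)c3cc(S(=O)(=O)c4ccccc4)ccc3C(F)(F)F)CC2)cc1` differs by 4-(dimethylamino)phenyl in place of neopentyl on a carbonyl carbon. For the measured compounds named here, the measured steps all swap small saturated groups at this carbonyl carbon and none moved the number beyond the scatter; no measured pair brings in an aromatic ring there. The expected outcome is therefore a step of about a 1.2-fold lower number from compound 3 to compound 4 (0.08 log units; within the scatter) in this assay, with wide uncertainty. Compound 4 is estimated at 100 nM in this assay, between 30 nM and 400 nM.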

Compound 4, half-maximal effective concentration: 830 nM
Estimate against measurement, compound 4: 8.3-fold (0.92 log units) below; the measured number lies above the stated range.
By their numbers in this assay, from the lowest: compounds 1, 2 and 3 (each within the scatter of the next); then compound 4.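

In this assay, the group on this carbonyl carbon does matter: 4-(dimethylamino)phenyl, the only aromatic ring among these groups, gives a 6.9-fold higher number from compound 3 to compound 4 (0.84 log units; beyond the scatter), a 9.2-fold higher number from compound 2 to compound 4 (0.96 log units; beyond the scatter) and a 14-fold higher number from compound 1 to compound 4 (1.14 log units; beyond the scatter), whereas the exchanges among the three earlier groups all stayed within the scatter. Effects on this read-out are therefore not indifferent to every group at this place. Nothing available explains the higher number of compound 4. The compounds shown leave open whether the step belongs to the aromatic ring itself or to its dimethylamino group; a plain phenyl on this carbonyl carbon would bear on that question.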